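Swapping a Pyridine-Bearing Side Chain for an Isobutyl Group

The source may report more compounds than this note shows. Statements on the series, on what has been measured and on what is new or still open speak of the compounds shown alone.

Measured so far:
compound 1, `Cc1csc2cc([C@H](C)Nc3ncnc(N)c3C#N)c(-c3cccc(CN4CCC(CN(C)Cc5ccccn5)CC4)c3)c(=O)n12`, in a physicochemical assay for lipophilicity; on this read-out higher numbers stand for higher lipophilicity and lower numbers for lower lipophilicity: 2
compound 2, `Cc1csc2cc([C@H](C)Nc3ncnc(N)c3C#N)c(-c3cccc(CN(C)CCCCN(C)Cc4ccccc4)c3)c(=O)n12`, in this assay: 2.2

Compound 1 holds the lower of the two numbers, but compound 2 sits only a little higher, and that gap falls inside the usual scatter of repeated measurements, so the two compounds cannot be told apart on this read-out. Compound 3, `Cc1csc2cc([C@H](C)Nc3ncnc(N)c3C#N)c(-c3cccc(CN4CCC(N(C)CC(C)C)CC4)c3)c(=O)n12`, has not yet been measured. It is built on the shared core of compound 1 and differs from it in one place: isobutyl(methyl)amino in place of (methyl((pyridin-2-yl)methyl)amino)methyl on a saturated ring carbon. The group that leaves carries one six-membered aromatic ring with one hetero atom and two hydrogen-bond acceptors; the group that enters has no ring and one hydrogen-bond acceptor, and is smaller. Going by the values given here, no step between two measured compounds tracks such a change, so the expectation rests on this difference alone. A small rise in this assay is expected, roughly at the edge of the scatter, the step from compound 1 to compound 3 being a number 0.30 log units higher from compound 1 to compound 3 (within the scatter). For compound 3 the value in this assay is estimated at 2.3, within the range 1.7 to 2.9.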

Compound 3, distribution coefficient: 1.7
Compound 3: middle estimate off by 0.60 log units, on the high side; measured number inside the range.
By their numbers in this assay, from the lowest: compounds 3, 1 and 2 (each within the scatter of the next, the first and the last beyond it).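

In this assay, putting isobutyl(methyl)amino in place of (methyl((pyridin-2-yl)methyl)amino)methyl on a saturated ring carbon gives a number 0.30 log units lower from compound 1 to compound 3 (within the scatter) and leaves the two compounds indistinguishable on this read-out. Going by these compounds alone, this is the first step between measured compounds that differ in only one place, so it is the first direct look at this position, which sits three ring bonds from the ring nitrogen. Here a group of 10 heavy atoms with a six-membered aromatic ring gives way to a group of 6 heavy atoms with no ring, and the read-out does not separate the pair; no measured evidence bearing on the cause of this small step is available.

This single step changes the ring, the heavy-atom count and the hydrogen-bond acceptor count together, so it cannot show how each of these would act alone in this assay. It also leaves open how the read-out would respond to a very different group on the same ring carbon, such as a carboxylic acid, a morpholine or a longer alkyl chain.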